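This account rests on a few compounds, and the source may have more. Where it says the series, first, only, none or still open, it means among the compounds named here.

Measured so far:
- compound 1 `COc1cc(-c2nn(-c3cccc(NC(=O)Nc4cc(C(F)(F)F)cc(C(F)(F)F)c4)c3)cc2-c2ccncc2)ccc1Cl`: 890 nM
- compound 2 `COc1cc(-c2nn(-c3cccc(NC(=O)c4cccc(C(F)(F)F)c4)c3)cc2-c2ccncc2)ccc1Cl`: 710 nM

Both compounds were tested in a functional assay on MDA-MB-435 cells (Homo sapiens) for inhibition, read by sulforhodamine B assay, with a stated time of 48 h; a higher number here means a weaker inhibitor, a lower number a stronger inhibitor. Compound 2 shows the lower of the two numbers, but compound 1 is only a little higher, and a gap of that size falls within the usual scatter of repeated measurements, so the two cannot be told apart on these data.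

Compound 3 `COc1cc(-c2nn(-c3cccc(NC(=O)Nc4ccc(Cl)c(Cl)c4)c3)cc2-c2ccncc2)ccc1Cl` has not yet been tested. It comes from compound 2 by one change: (3,4-dichlorophenyl)amino in place of 3-(trifluoromethyl)phenyl on a carbonyl carbon. The result is a urea like that in compound 1, but with a different ring at its end. Among the compounds with values here, no step between measured compounds reports how such a change moves the number, so the expectation rests on the closeness of compound 1 and compound 2 alone. The step from compound 2 to compound 3 is expected to be small, a 1.1-fold higher number from compound 2 to compound 3 (0.05 log units; within the scatter), with no direction beyond the scatter. Compound 3 is therefore estimated at 800 nM, likely between 300 nM and 2500 nM.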

Compound 3, half-maximal inhibitory concentration: 940 nM
The estimate for compound 3 lay 1.2-fold (0.07 log units) below the measured number; the range from low to high includes it.
By their numbers in this assay, from the lowest: compounds 2, 1 and 3 (each within the scatter of the next).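

Within the data shown here, the step of a 1.3-fold higher number from compound 2 to compound 3 (0.12 log units; within the scatter) in this assay is the first direct comparison of two compounds that differ in one place. On the carbonyl carbon, (3,4-dichlorophenyl)amino can stand in place of 3-(trifluoromethyl)phenyl without a change that can be read from these numbers, even though this turns the amide into a urea and adds a hydrogen-bond donor. No measurement shown explains this result.

As far as these compounds go, the step changes the link and the ring's substituents together, so the contribution of each remains open. Also open, from the compounds shown here alone, is how the number would respond to a quite different group on this carbonyl carbon, such as an amine, a carboxylic acid on the ring or a longer chain in place of the ring.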